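Replacing diethylamino with an oxolane side chain

The compounds below may be only part of what the source reports. "The series", "measured", "known", "first", "only" and "open" are said of these compounds alone.

Of the compounds shown here, three sharing one core have been measured in an ADME assay on L6 cells (Rattus norvegicus) for cytotoxicity (on this read-out lower numbers stand for stronger inhibition and higher numbers for weaker inhibition), so far. Compound 1 (`Cc1nc(-c2ccccn2)nc(N(C)C)c1Cl`) gives 115000 nM and compound 2 (`CCN(CC)c1nc(-c2ccccn2)nc(C)c1Cl`) gives 148000 nM as the two sit together at the top of the range. Compound 3 (`Cc1nc(-c2ccccn2)nc(NCCC2CCCCC2)c1Cl`) stands lower at 49500 nM on the same scale.

Compound 4 (`Cc1nc(-c2ccccn2)nc(NCC2CCOC2)c1Cl`) keeps the core of compound 2 but carries ((oxolan-3-yl)methyl)amino in place of diethylamino on an aromatic carbon. Among the compounds with values here, the one measured step at this place is a 1.3-fold higher number from compound 1 to compound 2 (0.11 log units; within the scatter) and it only exchanges one small amino group for another, so it says little about a side group with a ring. Compound 3, whose side group also holds a ring, gives 49500 nM and offers the only hint of a lower number.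

A modest move in this assay is therefore expected, and the estimated change is a 1.5-fold lower number from compound 2 to compound 4 (0.17 log units; within the scatter) with nothing beyond the scatter anticipated. For compound 4 the estimate is 100000 nM with an expected range of 50000 nM to 200000 nM once it is measured.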

Compound 4, half-maximal inhibitory concentration: 125000 nM
Estimate against measurement, compound 4: 1.3-fold (0.10 log units) below, and the stated range covers the measured number.
By their numbers in this assay, from the lowest: compound 3; then compounds 1, 4 and 2 (each within the scatter of the next).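

In this assay the ((oxolan-3-yl)methyl)amino group sits level with the two open-chain amino groups at this place, with a 1.2-fold lower number from compound 2 to compound 4 (0.07 log units; within the scatter) and a 1.1-fold higher number from compound 1 to compound 4 (0.04 log units; within the scatter) as the two steps. A ring in the side group is therefore not enough to bring the number down. The two side groups that hold a ring do part, with a 2.5-fold higher number from compound 3 to compound 4 (0.40 log units; beyond the scatter) as the step between them, so the lower number of compound 3 goes with its cyclohexyl-ended chain and not with every ring placed here.

Open, from the compounds shown here alone, is whether a longer chain ending in oxolane, or a cyclohexyl chain carrying an amine or a carboxylic acid, would stay with compound 3 or with compound 4. No outside measurement is at hand to explain the gap between compound 3 and compound 4.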